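Three Compounds at the Limit, a Fourth to Come

The source may hold more compounds than are shown below. What is called first, only, known or untested is meant among the compounds shown, and "the series" means these compounds.

The measured compounds and their values in an ADME assay on HEK293 cells (Homo sapiens) for cytotoxicity, with a stated time of 72 h; a lower number here means that less compound is needed, a higher number that more compound is needed for the effect:
compound 1, `Cc1cc(NC(=O)Nc2ccc(C)c(Cl)c2)c2ccccc2n1`, gives > 25000 nM, which is a limit of the assay and not a number.
compound 2, `Cc1ccc(NC(=O)Nc2cc(C)nc3ccccc23)cc1`, gives > 25000 nM, again a limit.
compound 3, `Cc1cc(NC(=O)Nc2ccccc2C(N)=O)c2ccccc2n1`, gives > 25000 nM, again a limit.

Compound 2 thus stands at the limit of this assay, and so do the other two measured compounds; all three share (the limit of > 25000 nM in this assay, at which 3 of the 3 values shown sit). Within the data shown here, the only step between measured compounds, a step that the two limits leave unreadable from compound 1 to compound 2, cannot be read in size because both of its ends are limits.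

Compound 4, `Cc1cc(NC(=O)Nc2ccc(N)cc2)c2ccccc2n1`, differs from compound 2 on an aromatic carbon: amino in place of methyl on an aromatic carbon. Among the measured compounds shown here, no measured step bears on this change, and the one measured step gives no size at all. For the measured compounds named here, nothing in these numbers points to a step in this assay in either direction, beyond the scatter or within it; the only guide is that every value sits at the limit. Compound 4 is therefore expected to give a limit again, and the estimated step is a step that the limit leaves unreadable from compound 2 to compound 4. For compound 4 the estimate is 30000 nM, expected to fall between 10000 nM and 100000 nM.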

Compound 4, half-maximal effective concentration: > 25000 nM
Compound 4 was reported as a limit; the forecaster's own chance of this, stated with the estimate: 80%; the middle value is on the limit's open side.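

No new step can be read from compound 2 to compound 4, because both results are limits of the assay and not numbers: the limit of > 25000 nM in this assay, at which 4 of the 4 values shown sit.

The compounds shown leave open what concentration, if any, would bring out the half-maximal effect in this assay, and so whether amino and methyl differ there at all.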